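This account rests on a few compounds, and the source may have more. Where it says the series, first, only, none or still open, it means among the compounds named here.

Working notes on the cinnamate series, cytotoxicity.

Compound 1 `CCOC(=O)/C=C/c1cc(Cl)ccc1OCc1nc(C)c(C)nc1C` is the ester with one chlorine on the aromatic ring. The measurements come from a functional assay on ECV-304 cells (Homo sapiens) for cytotoxicity, read by MTT assay, with stated times of 24 h and 12 h; on this read-out higher numbers stand for an effect only at larger amounts of compound and lower numbers for an effect already at smaller amounts. In this read-out compound 1 gives 16900000 nM. Compound 3 `Cc1nc(C)c(COc2ccc(Cl)cc2/C=C/C(=O)O)nc1C` is its acid and gives 9310000 nM: the change is hydrogen in place of ethyl on an oxygen next to a carbonyl group, and the step of a 1.8-fold lower number from compound 1 to compound 3 (0.26 log units; within the scatter) is within the scatter, so the two numbers cannot be ordered.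

Compound 2 `CCOC(=O)/C=C/c1cc(Br)cc(Br)c1OCc1nc(C)c(C)nc1C` carries two bromines instead. In this assay, among the compounds with values here, compound 2 gives 1590000 nM, which is the lowest of the three numbers so far, with compound 3 and compound 1 both beyond the scatter above it. The difference between the core of compound 2 and the core of compound 1 is not broken down here.

Compound 4 `Cc1nc(C)c(COc2c(Br)cc(Br)cc2/C=C/C(=O)O)nc1C` is the acid of compound 2. The change, (hydrogen in place of ethyl on an oxygen next to a carbonyl group), is the same kind of change as that from compound 1 to compound 3, at the same kind of place. The step from compound 2 to compound 4 in this assay is therefore expected to be about a 1.6-fold lower number from compound 2 to compound 4 (0.20 log units; within the scatter), resting on the step of a 1.8-fold lower number from compound 1 to compound 3 (0.26 log units; within the scatter). For compound 4 in this assay a value of 1000000 nM is estimated, with a range from 400000 nM to 3000000 nM.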

Compound 4, half-maximal effective concentration: 1970000 nM
Beside the measured number, compound 4's estimate is 2.0-fold (0.29 log units) below it, within the range that was stated.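

In this assay the step of a 1.2-fold higher number from compound 2 to compound 4 (0.09 log units; within the scatter) leaves the two numbers unordered. Set beside the earlier step, hydrogen in place of ethyl on an oxygen next to a carbonyl group reads alike on the two cores as far as these numbers can tell: the same change on two cores in this assay, a 1.8-fold lower number (0.26 log units; within the scatter) from compound 1 to compound 3 and a 1.2-fold higher number (0.09 log units; within the scatter) from compound 2 to compound 4, 2.2-fold (0.35 log units) apart, within the scatter of two such steps. This shows that the change gave no step beyond the scatter on either core, but two pairs give neither a direction for the step nor a rule for other cores of the series, and a small effect could lie hidden within the scatter.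

The compounds shown leave open whether an amide or a longer chain such as butyl in place of the ethyl ester would give a step beyond the scatter in this assay. Also open, going by these compounds, is how a core with a single bromine would read, as it would differ from the core of compound 1 in one place only.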